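This account rests on a few compounds, and the source may have more. Where it says the series, first, only, none or still open, it means among the compounds named here.

Measured in a functional assay on HeLa cells (Homo sapiens) for cytotoxicity, read by MTT assay, with a stated time of 72 h; a lower number here means a stronger inhibitor, a higher number a weaker inhibitor:
- Compound 1 `O=C(/C=C/c1cccc(Cl)c1Cl)Nc1cc2c(Nc3ccc(F)c(Cl)c3)ncnc2cc1O[C@H]1CCOC1`: 30500 nM
- Compound 2 `O=C(/C=C/c1cc(Br)c(O)c(Br)c1)Nc1cc2c(Nc3ccc(F)c(Cl)c3)ncnc2cc1O[C@H]1CCOC1`: 27700 nM
- Compound 3 `COc1ccc(/C=C/C(=O)Nc2cc3c(Nc4ccc(F)c(Cl)c4)ncnc3cc2O[C@H]2CCOC2)c(OC)c1OC`: 4830 nM

Compound 3 has the lowest number of the three, and its gaps to compound 1 and compound 2 both lie beyond the scatter. Compound 4 `O=C(/C=C/c1ccc(Br)cc1)Nc1cc2c(Nc3ccc(F)c(Cl)c3)ncnc2cc1O[C@H]1CCOC1` carries a different group on the same chain: 4-bromophenyl in place of 2,3,4-trimethoxyphenyl on a double-bonded chain carbon bound to a double-bonded chain carbon. Two measured steps bring in 2,3,4-trimethoxyphenyl, a 6.3-fold lower number from compound 1 to compound 3 (0.80 log units; beyond the scatter) and a 5.7-fold lower number from compound 2 to compound 3 (0.76 log units; beyond the scatter), both modest. They start from 2,3-dichlorophenyl and 3,5-dibromo-4-hydroxyphenyl, which differ only within the scatter, a 1.1-fold lower number from compound 1 to compound 2 (0.04 log units; within the scatter). Among the measured compounds shown here, no measured compound carries 4-bromophenyl itself, so the comparison is indirect. Reversing those steps, a modest rise in this assay is expected, perhaps slightly smaller than either. The expected step is a 4.1-fold higher number from compound 3 to compound 4 (0.62 log units; beyond the scatter). For compound 4 the estimated value is 20000 nM, with an expected range of 8000 nM to 40000 nM.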

Compound 4, half-maximal inhibitory concentration: 27500 nM
Beside the measured number, compound 4's estimate is 1.4-fold (0.14 log units) below it; the range from low to high includes it.
By their numbers in this assay, from the lowest: compound 3; then compounds 4, 2 and 1 (each within the scatter of the next).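

With 4-bromophenyl on the double-bonded chain carbon, this assay gives a 5.7-fold higher number from compound 3 to compound 4 (0.76 log units; beyond the scatter) and so takes the number back out of the range of compound 3. Among the compounds shown here, the other two steps, a 1.0-fold lower number from compound 2 to compound 4 (0.00 log units; within the scatter) and a 1.1-fold lower number from compound 1 to compound 4 (0.04 log units; within the scatter), place compound 4 within the scatter of both halogen-bearing compounds, leaving 2,3,4-trimethoxyphenyl as the only group of the four that stands apart. No evidence at hand bears on why this is so.

On these data alone, whether all three methoxy groups are needed remains open. So does how a phenyl ring bearing a single methoxy group, an amine or a carboxylic acid would read at this place.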